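A few compounds are considered here, and "the series" means these few. Any claim that something is new, unique, unknown or untested is made for them only; others in the source may bear on it.

In an ADME assay on microsomes from liver (Mus musculus) for metabolic stability, read by LC-MS, with a stated time of 10 min, tested at 0.5 uM (on this read-out higher numbers stand for a more stable compound and lower numbers for a less stable compound), three compounds have so far been measured. Compound 1 `c1cnc2c(c1)CCC[C@@H]2N(CCCN1CCNCC1)Cc1nc2ccccc2s1` gives 45%, compound 2 `CC(C)N1CCN(CCCN(C[C@H]2Cc3ccccc3CN2)[C@H]2CCCc3cccnc32)CC1` gives 58%, and compound 3 `c1cnc2c(c1)CCC[C@@H]2N(CCCN1CCNCC1)Cc1cc2ccccc2cn1` gives 74%. Compound 2 therefore stands second highest of the three: it sits above compound 1 and below compound 3, in each case by a gap beyond the usual scatter. Among the compounds with values here, the only step between measured compounds that differ in a single place is a number 29 percentage points higher from compound 1 to compound 3 (beyond the scatter), a modest gain that comes from exchanging 1,3-benzothiazol-2-yl for isoquinolin-3-yl on a saturated chain carbon bound to an amine nitrogen.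

The next compound, compound 4 `c1ccc2c(c1)CN[C@@H](CN(CCC1CCNCC1)[C@H]1CCCc3cccnc31)C2`, differs from compound 2 as follows: piperidin-4-yl in place of (4-isopropylpiperazin-1-yl)methyl on a saturated chain carbon, two bonds along the chain from an amine nitrogen. Within the data shown here, no measured pair speaks to this kind of change; the one known step concerns the aromatic group on the chain, not the group two bonds along the chain from the amine nitrogen. Without a directly relevant precedent, the expectation for compound 4 is held close to compound 2, with an estimated step of a number 3 percentage points lower from compound 2 to compound 4 (within the scatter), not beyond the scatter. On that basis compound 4 is estimated at 55%, with a range from 35% to 75%.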

Compound 4, percent of the compound remaining: 32%
The estimate for compound 4 lay 23 percentage points above the measured number; the whole stated range lies above it.
By their numbers in this assay, from the lowest: compound 4; then compound 1; then compound 2; then compound 3.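

In this assay, the group on a saturated chain carbon, two bonds along the chain from an amine nitrogen, proves able to move the read-out: piperidin-4-yl in place of (4-isopropylpiperazin-1-yl)methyl gives a number 26 percentage points lower from compound 2 to compound 4 (beyond the scatter), whereas the earlier single-place step, a number 29 percentage points higher from compound 1 to compound 3 (beyond the scatter), concerned only the aromatic group on the chain. This one exchange alters several things at once, going from 10 heavy atoms, 2 ring hetero atoms and 0 hydrogen-bond donors to 6 heavy atoms, 1 ring hetero atom and 1 hydrogen-bond donor, and the step alone cannot assign the fall to any one of them. No measurement shown bears on what lies behind the lower number.

From the compounds shown here alone, it remains open which feature carries the step, a question that a piperidin-4-yl bearing an isopropyl group on its ring nitrogen, or a (piperazin-1-yl)methyl group without the isopropyl, would help to separate. Going by these compounds, it is equally open whether the same exchange would give a step of similar direction and size with 1,3-benzothiazol-2-yl or isoquinolin-3-yl on the chain.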